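Aryl ether in place of benzylamine: compound 3

A few compounds are considered here, and "the series" means these few. Any claim that something is new, unique, unknown or untested is made for them only; others in the source may bear on it.

Two compounds are in hand in a functional assay on SK-MEL-2 cells (Homo sapiens) for inhibition, read by sulforhodamine B assay, with a stated time of 48 h; on this read-out lower numbers stand for stronger inhibition of growth and higher numbers for weaker inhibition of growth. Compound 1 `COc1ccc(CNc2nc3cc(N)cc(N)c3nc2-c2ccccc2)cc1OC` gives 8710 nM. Compound 2 `Nc1cc(N)c2nc(-c3ccccc3)c(NCc3ccc(F)cc3)nc2c1` gives 5250 nM. Going by the values given here, the one step between them: a 1.7-fold lower number from compound 1 to compound 2 (0.22 log units; within the scatter). Among the two numbers compound 2 carries the smaller one; its distance from compound 1 lies within the scatter, so no order is claimed.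

Compound 3 `Nc1cc(N)c2nc(-c3ccccc3)c(Oc3ccc(F)cc3)nc2c1` differs from compound 2 in 4-fluorophenoxy in place of (4-fluorobenzyl)amino on an aromatic carbon: the link to the fluorinated ring changes from nitrogen with a saturated chain carbon to oxygen. Among the compounds with values here, no measured step touches this link. The step from compound 1 to compound 2 varied only the substituents on the distal aryl ring and stayed within the scatter, so it offers no guide to the swap of the link itself. Within the data shown here, the expectation in this assay therefore rests on no direct precedent, and the working guess is a number near that of compound 2, with a wide band.

For compound 3 the estimated step is a 1.3-fold higher number from compound 2 to compound 3 (0.12 log units; within the scatter). Compound 3 is expected to give 7000 nM, between 2500 nM and 20000 nM.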

Compound 3, concentration for 50% growth inhibition: 42700 nM
Beside the measured number, compound 3's estimate is 6.1-fold (0.79 log units) below it; measured number outside the range, above it.
By their numbers in this assay, from the lowest: compounds 2 and 1 (each within the scatter of the next); then compound 3.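

In this assay, going by these compounds alone, this position, on the aromatic carbon next to the ring nitrogen and ortho to a phenyl group, proves sensitive to the link: 4-fluorophenoxy in place of (4-fluorobenzyl)amino gives an 8.1-fold higher number from compound 2 to compound 3 (0.91 log units; beyond the scatter) and so moves the read-out beyond the scatter, whereas the only earlier step, a 1.7-fold lower number from compound 1 to compound 2 (0.22 log units; within the scatter) and confined to the substituents on the distal ring, did not. The fluorinated ring is kept in this swap, so the loss of growth inhibition follows the link and not that ring, although the link changes in more than one way at once: the saturated chain carbon goes, oxygen replaces nitrogen, and 1 hydrogen-bond donor gives way to 0 hydrogen-bond donors. Nothing measured here accounts for the size of this step.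

Which of these changes carries the step remains open: a 4-fluorobenzyloxy group would keep the chain carbon with oxygen as the link, and a 4-fluoroanilino group would keep nitrogen without the chain carbon. Also open, going by these compounds, is how a longer chain, such as 2-(4-fluorophenyl)ethylamino, would read at this position.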